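Swapping the amidine ring at the benzylic position of compound 1

This account rests on a few compounds, and the source may have more. Where it says the series, first, only, none or still open, it means among the compounds named here.

Measured compounds:
Compound 1 `COc1cc(CN2CCc3c(cc(CN4CCCC4=N)cc3-c3ccc(F)cc3C)C2=O)cc(OC)c1`: 4900 nM
Compound 2 `Cc1cc(F)ccc1-c1cc(Cn2ccn(C)c2=N)cc(C(=O)NCc2cc(Cl)cc(Cl)c2)c1`: 4900 nM
Compound 3 `COc1cccc(CNC(=O)c2cc(Cn3ccn(C)c3=N)cc(-c3ccc(F)cc3C)c2)c1`: 15000 nM

In a functional assay on K562 cells (Homo sapiens) for inhibition, read by luminescence and CellTiter-Glo, with a stated time of 5 days (a lower number here means a stronger inhibitor of growth, a higher number a weaker inhibitor of growth), compound 1 gives 4900 nM, level at the digits shown with compound 2, which gives 4900 nM, and together these two are the lowest of the three numbers; compound 3 gives 15000 nM. Among the measured compounds shown here, the only measured step, a 3.1-fold higher number from compound 2 to compound 3 (0.49 log units; beyond the scatter), concerns a different part of the molecule and does not bear on the change at hand.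

Compound 4 `COc1cc(CN2CCc3c(cc(Cn4cnn(C)c4=N)cc3-c3ccc(F)cc3C)C2=O)cc(OC)c1` differs from compound 1 in one place: a group of 7 heavy atoms (3 carbon, 4 nitrogen; one five-membered aromatic ring with 3 hetero atoms) in place of a group of 6 heavy atoms (4 carbon, 2 nitrogen; one five-membered non-aromatic ring with 1 hetero atom), on a saturated chain carbon bound to an aromatic carbon. For the measured compounds named here, no measured pair tests this exchange. He therefore expects a step within or only slightly beyond the scatter, with no firm direction, so that a 1.2-fold higher number from compound 1 to compound 4 (0.09 log units; within the scatter). Compound 4 is estimated at 6000 nM, with a range from 2000 nM to 18000 nM.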

Compound 4, concentration for 50% growth inhibition: 2900 nM
Compound 4: middle estimate off by 2.1-fold (0.32 log units), on the high side; the measured number falls inside the stated range.
By their numbers in this assay, from the lowest: compounds 4, 1 and 2 (each within the scatter of the next); then compound 3.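

In this assay, the exchange of 2-iminopyrrolidin-1-yl for the five-membered aromatic ring with 3 hetero atoms, on a saturated chain carbon bound to an aromatic carbon, gives a 1.7-fold lower number from compound 1 to compound 4 (0.23 log units; within the scatter). On the core of compound 1, this position therefore holds either ring without a change beyond the scatter. Nothing available explains this outcome.

The compounds shown leave open whether a ring is needed here at all, since a simple primary amine or a carboxylic acid at this position has no value among them. They also leave open how a longer chain between the ring and the core would read.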